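The source may report more compounds than this note shows. Statements on the series, on what has been measured and on what is new or still open speak of the compounds shown alone.

Compound 1, `CN1CCCC[C@H]1/C=C/c1ccc(O)cc1`: 3.45 ug/mL
Compound 2, `Cc1cccc(C)c1/C=C/[C@@H]1CCCCN1`: 7.28 ug/mL
Compound 3, `Cc1ccc(/C=C/[C@@H]2CCCCN2)cc1`: 8.56 ug/mL

These three compounds were tested in a functional assay on A549 cells (Homo sapiens) for inhibition, read by MTT assay, with a stated time of 24 h; a lower number here means a stronger inhibitor, a higher number a weaker inhibitor. Compound 3 carries the highest of the three numbers, but its gap to compound 2 lies within the scatter of repeated measurements, so the two cannot be told apart on these data. Compound 1, on the other hand, gives a number well beyond the scatter from compound 3, and is the only clearly stronger inhibitor of the three in this assay.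

The next compound, compound 4, `COc1ccc(/C=C/[C@@H]2CCCCN2)cc1`, has not yet been measured. It differs from compound 3 in one place: methoxy in place of methyl on an aromatic carbon. For the measured compounds named here, no step between two measured compounds matches this change, so there is no direct precedent to lean on. Compound 1, which also bears an oxygen on its aromatic ring, gives 3.45 ug/mL, but it differs from compound 4 in more than one place, so it is only a loose hint.

On that basis a modest step is expected, toward a somewhat lower number: the estimated change is a 1.4-fold lower number from compound 3 to compound 4 (0.15 log units; within the scatter). Compound 4 is therefore expected to give about 6 ug/mL, with a likely range from 3 ug/mL to 12 ug/mL.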

Compound 4, half-maximal inhibitory concentration: 4.33 ug/mL
Compound 4: the middle estimate sits 1.4-fold (0.14 log units) above what was measured; measured number inside the range.
By their numbers in this assay, from the lowest: compounds 1, 4, 2 and 3 (each within the scatter of the next, the first and the last beyond it).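

In this assay, putting methoxy in place of methyl on the aromatic carbon, para to a group of 8 heavy atoms, gives a 2.0-fold lower number from compound 3 to compound 4 (0.30 log units; within the scatter). For the compounds shown here, this is the first direct reading of any single change, and it shows that this position accepts a group with one more heavy atom and one hydrogen-bond acceptor without a loss of inhibition that can be told from the scatter, although compound 3 and compound 4 themselves cannot be separated on these numbers. Nothing in the data shown bears on what lies behind this step.

From the compounds shown here alone, whether this position would respond more clearly to a different group remains open, for example a hydroxyl, a fluorine, an amine or a carboxylic acid, or to a longer chain such as ethoxy, since a single pair of close values says little about the range of groups allowed there. Compound 1 differs from compound 4 in more than one place, so it cannot show whether the oxygen on the aromatic ring matters on its own.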